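Swapping hydroxymethyl for hydrogen on compound 3

This account rests on a few compounds, and the source may have more. Where it says the series, first, only, none or still open, it means among the compounds named here.

Within the data shown here, in an ADME assay on HeLa cells (Homo sapiens) for cytotoxicity, with a stated time of 72 h (on this read-out lower numbers stand for higher toxicity in this test and higher numbers for lower toxicity in this test), compound 3 `COc1ccc(/C=C\c2cc(OC)c(OC)c(OC)c2)cc1NC(=O)[C@H](CO)NC(=O)[C@H](CCCNC(=N)N)NC(=O)[C@H](CCCNC(=N)N)NC(=O)c1ccccc1` gives 29.2 nM, the lowest of the three numbers so far. Compound 1 `COc1ccc(/C=C\c2cc(OC)c(OC)c(OC)c2)cc1NC(=O)[C@H](CO)NC(=O)[C@H](CCCNC(=N)N)NC(=O)[C@H](CCCCN)NC(=O)c1ccccc1` gives 61.8 nM, and compound 2 `COc1ccc(/C=C\c2cc(OC)c(OC)c(OC)c2)cc1NC(=O)CCNC(=O)[C@H](CCCNC(=N)N)NC(=O)[C@H](CCCNC(=N)N)NC(=O)c1ccccc1` gives 952 nM. The untested compound 4 `COc1ccc(/C=C\c2cc(OC)c(OC)c(OC)c2)cc1NC(=O)CNC(=O)[C@H](CCCNC(=N)N)NC(=O)[C@H](CCCNC(=N)N)NC(=O)c1ccccc1` differs from compound 3 by hydrogen in place of hydroxymethyl on a saturated chain carbon bound to an amide-type nitrogen and a carbonyl carbon. Among the measured compounds shown here, the only measured step, a 2.1-fold lower number from compound 1 to compound 3 (0.33 log units; beyond the scatter), is modest and concerns a different group, so it offers little guidance. Compound 2 at 952 nM shows that numbers in this small set can run much higher, so a rise in this assay is expected. The estimated step is a 5.1-fold higher number from compound 3 to compound 4 (0.71 log units; beyond the scatter). For compound 4 the expected value is 150 nM, within an estimated range of 35 nM to 700 nM.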

Compound 4, half-maximal cytotoxic concentration: 7.2 nM
Beside the measured number, compound 4's estimate is 21-fold (1.32 log units) above it, outside the stated range (below it).
By their numbers in this assay, from the lowest: compound 4; then compound 3; then compound 1; then compound 2.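

In this assay, hydrogen in place of hydroxymethyl on a saturated chain carbon bound to an amide-type nitrogen and a carbonyl carbon gives a 4.1-fold lower number from compound 3 to compound 4 (0.61 log units; beyond the scatter). The hydroxymethyl is therefore not required for a low number here, and this position affects the read-out beyond the scatter. Nothing available explains the shift.

A methyl group at this carbon would help show whether the change in the number follows the oxygen or the whole group. From the compounds shown here alone, how an amine or a longer chain would behave at this carbon remains open.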